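Chloro in Place of Hydrogen: From Compound 1 to Compound 3

This account rests on a few compounds, and the source may have more. Where it says the series, first, only, none or still open, it means among the compounds named here.

Compound 1, `O=C(CSc1nc2cccnc2[nH]1)Nc1ccccc1`: 30%
Compound 2, `COc1ccc(NC(=O)C(C)Sc2nc3cccnc3[nH]2)cc1OC`: 6%

Of the compounds shown here, two have been measured in an assay on isolated protein for inhibition of Ectonucleotide pyrophosphatase/phosphodiesterase family member 1 (Homo sapiens), tested at 10 uM; a higher number here means more inhibition at the concentration tested (going by the name of the read-out), a lower number less inhibition. Compound 1 `O=C(CSc1nc2cccnc2[nH]1)Nc1ccccc1` gives 30%, the higher of the two numbers; compound 2 `COc1ccc(NC(=O)C(C)Sc2nc3cccnc3[nH]2)cc1OC` gives 6%, a number that lies beyond the usual scatter below it. These two differ in more than one place, so their gap says nothing about any single change.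

Compound 3 `O=C(CSc1nc2cccnc2[nH]1)Nc1ccc(Cl)cc1` has not yet been measured. It differs from compound 1 in one place: chloro in place of hydrogen on an aromatic carbon. Within the data shown here, no measured pair here shows what such an exchange alone does, so the expectation rests on compound 1, at 30%, with only a small step in either direction anticipated. The expected step is a number 6 percentage points higher from compound 1 to compound 3 (within the scatter), most likely a small rise that may stay within the scatter. Compound 3 is therefore estimated at 36%, within a range from 15% to 58%.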

Compound 3, a percentage reported as inhibition, at one concentration (the size of the read-out at that concentration, not a potency): 17%
The estimate for compound 3 lay 19 percentage points above the measured number; the measured number falls inside the stated range.
By their numbers in this assay, from the lowest: compound 2; then compound 3; then compound 1.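

In this assay, among these compounds, the exchange of phenyl for 4-chlorophenyl gives a number 13 percentage points lower from compound 1 to compound 3 (beyond the scatter), and this is the first comparison here in which only one thing changes. It shows that this place on the aromatic ring, para to a large group, is not indifferent to substitution: a single chlorine atom in place of a hydrogen is enough to lower the read-out. No measurement is available that would explain the fall, so the data record its direction and size but not its cause.

One exchange cannot show whether any added group here lowers the number or whether this happens with chloro in particular. A fluoro group, an amine or a carboxylic acid at this place, or chloro on another carbon of the ring, would help to separate these possibilities.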